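Working notes: from compound 3 to compound 4

The source may hold more compounds than are shown below. What is called first, only, known or untested is meant among the compounds shown, and "the series" means these compounds.

In a physicochemical assay for lipophilicity, using the shake flask method, in phosphate buffer, measured as octanol-water partition, with a stated time of 30 min, at pH 7.4 (a lower number here means a more polar compound, a higher number a more lipophilic compound), compound 1 (`Cc1nccn1-c1cnc(NCc2c(F)ccc3c2CCO3)c2cn[nH]c(=O)c12`) gives 2.1, compound 2 (`Cn1nccc1-c1cnc(NCc2c(F)ccc3c2CCO3)c2cn[nH]c(=O)c12`) gives 2.6 and compound 3 (`Cc1nc(CO)ccc1-c1cnc(NCc2c(F)ccc3c2CCO3)c2cn[nH]c(=O)c12`) gives 2.4. Compound 3 therefore lies within the scatter of both other compounds. One measured step clears the scatter: a number 0.50 log units higher from compound 1 to compound 2 (beyond the scatter). The other two do not: a number 0.30 log units higher from compound 1 to compound 3 (within the scatter) and a number 0.20 log units lower from compound 2 to compound 3 (within the scatter).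

Compound 4 (`CC(=O)N1CCC(c2cnc(NCc3c(F)ccc4c3CCO4)c3cn[nH]c(=O)c23)CC1`) carries 1-acetylpiperidin-4-yl in place of 6-(hydroxymethyl)-2-methylpyridin-3-yl on an aromatic carbon. Within the data shown here, no measured step introduces a non-aromatic ring, so all three steps bear on this change only indirectly, by showing how far exchanges at this carbon have moved the number. The largest of them, a number 0.50 log units higher from compound 1 to compound 2 (beyond the scatter), sets the scale, and a small downward shift in this assay, not clearly beyond the scatter, is expected. The expected change is a number 0.30 log units lower from compound 3 to compound 4 (within the scatter). Compound 4 is estimated at 2.1, with an expected range from 1.6 to 2.6.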

Compound 4, distribution coefficient: 2.9
Estimate against measurement, compound 4: 0.80 log units below; measured number above the stated range.
By their numbers in this assay, from the lowest: compounds 1, 3, 2 and 4 (each within the scatter of the next, the first and the last beyond it).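

In this assay the change to 1-acetylpiperidin-4-yl, the only non-aromatic ring at this aromatic carbon among the compounds shown, gives a number 0.50 log units higher from compound 3 to compound 4 (beyond the scatter) and a number 0.80 log units higher from compound 1 to compound 4 (beyond the scatter) while a number 0.30 log units higher from compound 2 to compound 4 (within the scatter) leaves compound 4 unseparated from compound 2. The leaving and entering groups hold the same heavy atoms in number and kind, so this step comes with no change in that count, while the ring type, the double bond outside aromatic rings and the hydrogen-bond donor of the hydroxymethyl do differ. No measurement shown gives a reason for the step.

The compounds shown do not separate the loss of the aromatic ring from the acetyl on the piperidine nitrogen or from the loss of the hydroxymethyl. Going by these compounds, how a free piperidine amine, a methanesulfonyl in place of the acetyl, or a 2-methylpyridin-3-yl without the hydroxymethyl would read at this carbon remains open.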